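The compounds below may be only part of what the source reports. "The series", "measured", "known", "first", "only" and "open" are said of these compounds alone.

Measured compounds:
compound 1 `Cn1ccc(-c2ccc(Oc3ccc(F)cc3)cc2)n1`, 690 nM
compound 2 `CN(C)C(=O)n1ccc(-c2ccc(Oc3ccc(F)cc3)cc2)n1`, 340 nM

In an assay on HEK293 cells for binding affinity to sodium channel protein type 4 subunit alpha (Homo sapiens) (a lower number here means a stronger inhibitor, a higher number a weaker inhibitor), compound 2 holds the lowest of the two numbers; its nearest neighbour, compound 1, gives 690 nM, and the step of a 2.0-fold lower number from compound 1 to compound 2 (0.31 log units; beyond the scatter) lies beyond the scatter. Compound 3 `Fc1ccc(Oc2ccc(-c3cc[nH]n3)cc2)cc1` is not yet measured. It differs from compound 2 by hydrogen in place of dimethylcarbamoyl on an aromatic nitrogen. Among the measured compounds shown here, only the step from compound 1 to compound 2 touches this nitrogen, and it was modest. For the measured compounds named here, the group now leaving was the one that lowered the number, so compound 3 is expected to move back toward compound 1, the step of a 1.8-fold higher number from compound 2 to compound 3 (0.25 log units; within the scatter) being estimated to stay modest. Compound 3 is estimated at 600 nM, within 200 nM to 1800 nM in this assay.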

Compound 3, inhibition constant: 200 nM
Beside the measured number, compound 3's estimate is 3.0-fold (0.48 log units) above it; low and high end bracket the measured number.
By their numbers in this assay, from the lowest: compounds 3 and 2 (each within the scatter of the next); then compound 1.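

In this assay, the dimethylcarbamoyl group proves unnecessary for the lower number seen with compound 2, since removing it to leave hydrogen on the aromatic nitrogen gives a 1.7-fold lower number from compound 2 to compound 3 (0.23 log units; within the scatter). Methyl is instead the group that stands apart at this position, with a 3.5-fold lower number from compound 1 to compound 3 (0.54 log units; beyond the scatter). Nothing available explains this difference. The compounds shown leave open whether an ethyl group or an acetyl group on this nitrogen would give a number near that of compound 1 or near those of compound 2 and compound 3.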